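Extending the Amide Chain of Compound 1

A few compounds are considered here, and "the series" means these few. Any claim that something is new, unique, unknown or untested is made for them only; others in the source may bear on it.

Measured so far in a functional assay on KYSE-450 cells (Homo sapiens) for inhibition, read by MTT assay, with a stated time of 48 h; a higher number here means a weaker inhibitor, a lower number a stronger inhibitor:
compound 1 `CCC(=O)N(Cc1ccc(OC)c(O)c1)c1cc(OC)c(OC)c(OC)c1` gives 98 nM
compound 2 `COc1ccc(CNc2cc(OC)c(OC)c(OC)c2)cc1` gives 4890 nM
compound 3 `COc1ccc(CNc2cc(OC)c(OC)c(OC)c2)cc1F` gives 46200 nM

Compound 1 stands lowest of the three numbers, so it is the strongest inhibitor shown; compound 2 comes nearest with a higher number beyond the scatter, and compound 3 stands furthest, higher again and also beyond the scatter. Within the data shown here, the only step measured between two compounds that differ in one place is a 9.4-fold higher number from compound 2 to compound 3 (0.98 log units; beyond the scatter), a change of fluoro for hydrogen on an aromatic carbon. That concerns a different group at a different place from the change now considered, so it gives no guidance.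

Compound 4 `CCCCC(=O)N(Cc1ccc(OC)c(O)c1)c1cc(OC)c(OC)c(OC)c1` differs from compound 1 by ethyl in place of hydrogen on a saturated chain carbon, two bonds along the chain from a carbonyl carbon. The shared core and the rest of compound 1 are kept. Among the measured compounds shown here, no measured step speaks to lengthening this chain, so the expectation rests on compound 1 alone, and the step of a 1.5-fold higher number from compound 1 to compound 4 (0.18 log units; within the scatter) is expected to stay within the scatter. Compound 4 is therefore estimated at 150 nM, with a range of 40 nM to 600 nM.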

Compound 4, half-maximal inhibitory concentration: 300 nM
The estimate for compound 4 lay 2.0-fold (0.30 log units) below the measured number; the range from low to high includes it.
By their numbers in this assay, from the lowest: compound 1; then compound 4; then compound 2; then compound 3.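

In this assay ethyl in place of hydrogen on a saturated chain carbon, two bonds along the chain from a carbonyl carbon, gives a 3.1-fold higher number from compound 1 to compound 4 (0.49 log units; beyond the scatter) and so weakens inhibition. Among these compounds, this is the first measured step at this chain, and it shows that the position is sensitive to change, although the loss is modest and the longer chain is tolerated to that extent. No measurement shown here bears on the reason for this loss.

From the compounds shown here alone, with one step at this position, it remains open whether inhibition keeps falling as the chain grows or whether a longer chain, such as hexanoyl, behaves differently. Going by these compounds, it is equally open how a shorter acetyl group, a branched isopropyl end or a cyclopropyl ring would fare in place of the propanoyl chain of compound 1.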